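Swapping the fused dioxane ring for a carbocycle

This account rests on a few compounds, and the source may have more. Where it says the series, first, only, none or still open, it means among the compounds named here.

Compound 1, `O=C(c1ccc2c(c1)OCCO2)C1CCN(Cc2coc(-c3ccc(F)cc3)n2)CC1`, carries the core shared by all compounds here. In an ADME assay on HEK293 cells (Homo sapiens) for cytotoxicity, read by MTT assay, with a stated time of 36 h (a higher number here means a weaker inhibitor, a lower number a stronger inhibitor), compound 1 gives a value that is a limit of the assay, > 150 ug/mL. Compound 2, `O=C(c1ccc2c(c1)OCCO2)C1CCN(Cc2coc(-c3ccc(Br)cc3)n2)CC1`, also gives a limit, > 150 ug/mL. Compound 3, `COc1ccc(-c2nc(CN3CCC(C(=O)c4ccc5c(c4)OCCO5)CC3)co2)cc1`, likewise gives a limit, > 150 ug/mL. All three measured values thus sit at the limit of > 150 ug/mL in this assay, at which 3 of the 3 values shown sit, so no number can be read off for compound 1; it stands at the ceiling together with the other two.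

The new compound 4, `O=C(c1ccc2c(c1)CCCC2)C1CCN(Cc2coc(-c3ccc(F)cc3)n2)CC1`, differs from compound 1 by 1,2,3,4-tetrahydronaphthalen-6-yl in place of 2,3-dihydro-1,4-benzodioxin-6-yl on a carbonyl carbon. The measured steps all concern the group on the aromatic ring attached to the oxazole rather than the ring on the carbonyl: a step that the two limits leave unreadable from compound 1 to compound 2, a step that the two limits leave unreadable from compound 1 to compound 3 and a step that the two limits leave unreadable from compound 2 to compound 3. Going by the values given here, each is unreadable in size, so none speaks to a change at the carbonyl, and no step can be carried over from them. With every measured compound sitting at the limit, the step expected for this change is a number no higher from compound 1 to compound 4 (the limit leaves the size open). The estimate for compound 4 is therefore 150 ug/mL, between 75 ug/mL and 300 ug/mL, most likely reported again only as a limit.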

Compound 4, half-maximal inhibitory concentration: > 150 ug/mL
Compound 4: only a limit was reported; the forecaster's own chance of this, stated with the estimate: 75%; the middle value sits exactly at the limit.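

In this assay compound 4 gives > 150 ug/mL, which is a limit and not a number. Compound 1 also stands at a limit, so no step can be read between compound 1 and compound 4: the limit of > 150 ug/mL in this assay, at which 4 of the 4 values shown sit.

The compounds shown leave open whether swapping 2,3-dihydro-1,4-benzodioxin-6-yl for 1,2,3,4-tetrahydronaphthalen-6-yl changes anything in this assay.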